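Compound 3 to Compound 4: One Group Exchanged

A few compounds are considered here, and "the series" means these few. Any claim that something is new, unique, unknown or untested is made for them only; others in the source may bear on it.

Three compounds sharing one core, and differing in a single group, have been tested in a functional assay on HCT-116 cells (Homo sapiens) for inhibition, read by CCK-8 assay, with a stated time of 48 h; on this read-out lower numbers stand for stronger inhibition and higher numbers for weaker inhibition. Here compound 1 `COc1cc(-c2ccnc3cc(-c4ccc(Cl)cc4)nn23)cc(OC)c1OC` gives 3340 nM, compound 2 `COc1cc(-c2ccnc3cc(-c4ccc(C)c(C)c4)nn23)cc(OC)c1OC` gives 261 nM and compound 3 `COc1cc(-c2ccnc3cc(-c4ccc5ccn(C)c5c4)nn23)cc(OC)c1OC` gives 1040 nM. Compound 3 therefore holds the middle place of the three, clearly apart from both others. Compound 4 `COc1ccc(-c2cc3nccc(-c4cc(OC)c(OC)c(OC)c4)n3n2)cc1` is still unmeasured. In it, 4-methoxyphenyl stands in place of 1-methyl-1H-indol-6-yl on an aromatic carbon: 4-methoxyphenyl in place of 1-methyl-1H-indol-6-yl on an aromatic carbon.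

Exchanging this group has mattered so far. The change gave a 13-fold lower number from compound 1 to compound 2 (1.11 log units; beyond the scatter), while the other two exchanges gave a 3.2-fold lower number from compound 1 to compound 3 (0.51 log units; beyond the scatter) and a 4.0-fold higher number from compound 2 to compound 3 (0.60 log units; beyond the scatter). Those steps point both ways, and none of them involves 4-methoxyphenyl, so they set a likely span without fixing a direction. The substituted phenyl groups of compound 1 and compound 2 fall on either side of compound 3. The estimated change is a 1.2-fold lower number from compound 3 to compound 4 (0.06 log units; within the scatter), so no step beyond the scatter is expected. Compound 4 is expected at about 900 nM, within an estimated range of 280 nM to 3000 nM.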

Compound 4, half-maximal inhibitory concentration: 404 nM
The estimate for compound 4 lay 2.2-fold (0.35 log units) above the measured number; the measured number falls inside the stated range.
By their numbers in this assay, from the lowest: compounds 2 and 4 (each within the scatter of the next); then compound 3; then compound 1.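

Exchanging 1-methyl-1H-indol-6-yl for 4-methoxyphenyl gives a 2.6-fold lower number from compound 3 to compound 4 (0.41 log units; beyond the scatter) in this assay, so a single-ring group can outdo this two-ring group at this position. Methoxy in place of chloro gives an 8.3-fold lower number from compound 1 to compound 4 (0.92 log units; beyond the scatter), while 4-methoxyphenyl in place of 3,4-dimethylphenyl gives a 1.5-fold higher number from compound 2 to compound 4 (0.19 log units; within the scatter), which leaves compound 2 and compound 4 indistinguishable and shows that two differently substituted phenyl groups can reach the same level, whereas 4-chlorophenyl in compound 1 does not. Nothing on hand explains why these groups differ.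

On these data alone, it remains open whether an ethoxy group, a longer chain, in place of the methoxy would keep the number near that of compound 4. An amine or a carboxylic acid on the same phenyl ring is equally untested in the compounds shown here.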